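The source may report more compounds than this note shows. Statements on the series, on what has been measured and on what is new or still open speak of the compounds shown alone.

compound 1 `CCCS(=O)(=O)Nc1ccc(F)c(C(=O)c2n[nH]c3ncc(-c4ccccc4F)cc23)c1F`: 2%
compound 2 `CCCS(=O)(=O)Nc1ccc(F)c(C(=O)c2n[nH]c3ncc(-c4ccc(OC)cc4)cc23)c1F`: 4.2%
compound 3 `CCCS(=O)(=O)Nc1ccc(F)c(C(=O)c2n[nH]c3ncc(-c4ccc(Cl)cc4Cl)cc23)c1F`: 22%

Of the compounds shown here, three built on one shared core have been tested in an assay for binding affinity to dual specificity mitogen-activated protein kinase kinase 4 (Homo sapiens), read by KINOMEscan, tested at 100 nM; on this read-out lower numbers stand for a stronger effect and higher numbers for a weaker effect at the one concentration tested. Compound 3 gives the highest number of the three, and both steps leading to it, a number 20 percentage points higher from compound 1 to compound 3 (beyond the scatter) and a number 17.8 percentage points higher from compound 2 to compound 3 (beyond the scatter), lie beyond the scatter, so compound 3 is the weakest binder measured so far. Compound 4 `CCCS(=O)(=O)Nc1ccc(F)c(C(=O)c2n[nH]c3ncc(-c4ccc(-c5nnn[nH]5)cc4)cc23)c1F` differs from compound 3 only in the ring hanging from the core: 4-(1H-tetrazol-5-yl)phenyl in place of 2,4-dichlorophenyl on an aromatic carbon.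

Every measured step is an exchange of this same ring at this same place, so all three bear on the question. The exchange a number 2.2 percentage points higher from compound 1 to compound 2 (within the scatter) stayed within the scatter, while only the move to 2,4-dichlorophenyl raised the number in a modest way. The incoming 4-(1H-tetrazol-5-yl)phenyl resembles 4-methoxyphenyl in carrying a single substituent in its 4 position, so the number is expected to fall back toward that of compounds 1 and 2, a modest drop of about a number 14 percentage points lower from compound 3 to compound 4 (beyond the scatter). Compound 4 is therefore estimated at 8%, most likely between 2% and 30%.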

Compound 4, a percentage reported as activity, at one concentration (the size of the read-out at that concentration, not a potency): 0.15%
Compound 4: the middle estimate sits 7.9 percentage points above what was measured; measured number outside the range, below it.
By their numbers in this assay, from the lowest: compounds 4, 1 and 2 (each within the scatter of the next); then compound 3.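

The position on the shared core accepts a group with a second ring: in this assay, the exchange of 2,4-dichlorophenyl for 4-(1H-tetrazol-5-yl)phenyl gives a number 21.9 percentage points lower from compound 3 to compound 4 (beyond the scatter) and returns the number to the range of the two lowest earlier compounds. With 1H-tetrazol-5-yl in place of methoxy the step is a number 4.1 percentage points lower from compound 2 to compound 4 (within the scatter) and with the whole 4-(1H-tetrazol-5-yl)phenyl in place of 2-fluorophenyl it is a number 1.9 percentage points lower from compound 1 to compound 4 (within the scatter) so compound 4 cannot be told apart from either compound. No measured information on the cause of these results is at hand.

Going by these compounds, whether a carboxylic acid or an amine in the 4 position of the phenyl ring would give a similar number stays open. On these data alone, how much of the higher number of compound 3 goes with each of its two chlorine atoms also stays open, and 4-chlorophenyl would speak to that.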